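Dichloroacetanilides: fluoro versus trifluoromethyl on the distal ring

The compounds below may be only part of what the source reports. "The series", "measured", "known", "first", "only" and "open" are said of these compounds alone.

Measured compounds, with their half-maximal inhibitory concentrations in a functional assay on NCI-H460 cells (Homo sapiens) for cytotoxicity, read by MTT assay, with a stated time of 68 h; on this read-out lower numbers stand for stronger inhibition and higher numbers for weaker inhibition:
- compound 1 `O=C(Nc1cccc(-c2cccc(F)c2)c1)C(Cl)Cl`: a limit of the assay, > 50000 nM
- compound 2 `O=C(Nc1cccc(-c2cccc(C(F)(F)F)c2)c1)C(Cl)Cl`: 30200 nM
- compound 3 `O=C(Nc1cccc(-c2ccc(F)cc2)c1)C(Cl)Cl`: a limit of the assay, > 50000 nM

Compound 1 and compound 3 carry the same atoms joined differently; the difference between the two cores is not broken down here. Among the measured compounds shown here, the one step measured on the series is the change (trifluoromethyl in place of fluoro on an aromatic carbon), which gave an at least 1.6-fold lower number from compound 1 to compound 2 (0.21 log units; that floor lies within the scatter). On these data alone, that step starts from a limit and is only a floor, so its true size is unknown; the relevant fact is the limit of > 50000 nM in this assay, at which 2 of the 3 values shown sit, at which compound 1 and compound 3 both sit.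

Compound 4 `O=C(Nc1cccc(-c2ccc(C(F)(F)F)cc2)c1)C(Cl)Cl` has not yet been measured in this assay. From compound 3 it differs by trifluoromethyl in place of fluoro on an aromatic carbon. This is the same kind of change as that from compound 1 to compound 2, but at a different place: there the trifluoromethyl enters meta to a large group, here para to a large group. For the measured compounds named here, with only one measured example of this change, and that one bounded by a limit, the expectation for compound 4 rests on the floor given by an at least 1.6-fold lower number from compound 1 to compound 2 (0.21 log units; that floor lies within the scatter) and on the weak value of compound 2; the step from compound 3 to compound 4 is estimated at an at least 1.4-fold lower number from compound 3 to compound 4 (0.15 log units; that floor lies within the scatter). Compound 4 is accordingly expected to give roughly 35000 nM in this assay, within 15000 nM to 100000 nM, with a real chance that the assay again reports only a limit.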

Compound 4, half-maximal inhibitory concentration: 33600 nM
For compound 4 the middle estimate is 1.0-fold (0.02 log units) above the measured one; measured number inside the range.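

In this assay, trifluoromethyl in place of fluoro on an aromatic carbon, here para to a large group, gave an at least 1.4-fold lower number from compound 3 to compound 4 (0.17 log units; that floor lies within the scatter). On both cores the change turns a limit of the assay into a measured number, so the direction of the bounded steps agrees across the two cores, although each floor is small and the two steps can be compared only as floors: the same change on two cores in this assay, an at least 1.6-fold lower number (0.21 log units; that floor lies within the scatter) from compound 1 to compound 2 and an at least 1.4-fold lower number (0.17 log units; that floor lies within the scatter) from compound 3 to compound 4; the limit leaves it open whether they differ. This does not show that the change carries over with the same size, or establish the true size of either step, as both steps start from limits: the limit of > 50000 nM in this assay, at which 2 of the 4 values shown sit.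

The series thus supports no more than a weak, bounded reading of this change on two cores, and all the measured numbers remain weak in this assay. Left open is how far the number in this assay depends on the trifluoromethyl itself, which could be tested by putting a nitrile, a methoxy group, an amine or a carboxylic acid at the same places, and whether any such group would give a fully measured pair from which the size of a step could be read.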